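Trading a Methyl for a Fluorine on the Outer Ring

The compounds below may be only part of what the source reports. "The series", "measured", "known", "first", "only" and "open" are said of these compounds alone.

Of the compounds shown here, three with one shared core have been tested in an in vitro functional assay on HEK293-A cells for positive allosteric modulation of metabotropic glutamate receptor 5 (Homo sapiens), read by FLIPR and calcium flux; on this read-out lower numbers stand for an effect already at smaller amounts and higher numbers for an effect only at larger amounts of compound. Compound 1 `O=C1CC(c2nc(-c3cccc(Cl)c3)no2)CN1c1ccc(Cl)c(Cl)c1` gives 460 nM, compound 2 `O=C1CC(c2nc(-c3ccc(Cl)cc3)no2)CN1c1ccc(Cl)c(Cl)c1` gives 1100 nM, and compound 3 `Cc1cccc(-c2noc(C3CC(=O)N(c4ccc(Cl)c(Cl)c4)C3)n2)c1` gives 390 nM, the lowest of the three numbers, within the scatter of compound 1 and clearly apart only from compound 2. Compound 4 `O=C1CC(c2nc(-c3ccc(F)cc3)no2)CN1c1ccc(Cl)c(Cl)c1` is still unmeasured and differs from compound 3 in a single place: 4-fluorophenyl in place of 3-methylphenyl on an aromatic carbon. Going by the values given here, two measured steps bear on this change. a 2.8-fold lower number from compound 2 to compound 3 (0.45 log units; beyond the scatter), and a 2.4-fold higher number from compound 1 to compound 2 (0.38 log units; beyond the scatter). In both, the 4-chlorophenyl went with the higher number. Because of a 2.8-fold lower number from compound 2 to compound 3 (0.45 log units; beyond the scatter), a modest rise is expected, a 2.3-fold higher number from compound 3 to compound 4 (0.36 log units; beyond the scatter), though fluorine has not yet been tried. Compound 4 is estimated at 900 nM, between 400 nM and 2500 nM.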

Compound 4, half-maximal effective concentration: 2300 nM
Compound 4: the middle estimate sits 2.6-fold (0.41 log units) below what was measured, within the range that was stated.
By their numbers in this assay, from the lowest: compounds 3 and 1 (each within the scatter of the next); then compound 2; then compound 4.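

In this assay the 4-fluorophenyl group brings the two largest steps seen so far, a 5.9-fold higher number from compound 3 to compound 4 (0.77 log units; beyond the scatter) and a 5.0-fold higher number from compound 1 to compound 4 (0.70 log units; beyond the scatter) against the two 3-substituted phenyl groups. The halogen itself also counts: fluoro in place of chloro gives a 2.1-fold higher number from compound 2 to compound 4 (0.32 log units; beyond the scatter) on an otherwise unchanged compound. Nothing measured here explains these differences. Still open, from the compounds shown here alone, is whether 3-fluorophenyl would match the low numbers of the 3-chlorophenyl and 3-methylphenyl groups, and how an amine or a methoxy group on the outer ring would fare.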